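A few compounds are considered here, and "the series" means these few. Any claim that something is new, unique, unknown or untested is made for them only; others in the source may bear on it.

Going by the values given here, in a functional assay on MCF7 cells (Homo sapiens) for inhibition, read by MTT assay, with a stated time of 48 h (a higher number here means a weaker inhibitor, a lower number a stronger inhibitor), compound 1 `O=C(CC(c1ccc(Cl)cc1)C(C(=O)Nc1ccccn1)C(=O)Nc1ccccn1)c1ccccc1` gives 19100 nM, and compound 2 `O=C(CC(c1c(Cl)cccc1Cl)C(C(=O)Nc1ccccn1)C(=O)Nc1ccccn1)c1ccccc1` gives 16700 nM, so compound 1 stands level with the only other measured compound, within the usual scatter. Compound 3 `O=C(CC(c1ccc(Cl)cc1)C(C(=O)Nc1ccccn1)C(=O)Nc1ccccn1)c1ccc2ccccc2c1` keeps the core of compound 1 and differs in one place: naphthalen-2-yl in place of phenyl on a carbonyl carbon. This puts naphthalen-2-yl in place of phenyl on a carbonyl carbon, turning benzoyl into (naphthalen-2-yl)carbonyl. Among the compounds with values here, the one measured step, a 1.1-fold lower number from compound 1 to compound 2 (0.06 log units; within the scatter), changes a different part of the molecule, so it offers only indirect guidance, and no measurement yet tests this carbonyl substituent. It gives no reason to expect a large move, so no step beyond the scatter is expected in this assay, and any lean toward a lower number is tentative. The expected change is a 1.4-fold lower number from compound 1 to compound 3 (0.13 log units; within the scatter). For compound 3 the estimated value is 14000 nM, with an expected range of 5000 nM to 35000 nM.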

Compound 3, half-maximal inhibitory concentration: 50000 nM
The estimate for compound 3 lay 3.6-fold (0.55 log units) below the measured number; measured number above the stated range.
By their numbers in this assay, from the lowest: compounds 2 and 1 (each within the scatter of the next); then compound 3.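

Placing naphthalen-2-yl in place of phenyl on a carbonyl carbon gives the first change in this assay that moves the number beyond the scatter (a 2.6-fold higher number from compound 1 to compound 3 (0.42 log units; beyond the scatter)), though the step is modest. The earlier comparison of compound 1 with compound 2 changed a different part of the molecule and stayed within the scatter, so this carbonyl substituent is the only place shown to affect the number, and going from one aromatic ring to two here weakens inhibition. Nothing available explains this loss of inhibition.

As far as these compounds go, it remains open whether a smaller group on this carbonyl carbon, such as methyl, or a phenyl carrying a methoxy group or an amine, would keep or improve inhibition. From the compounds shown here alone, whether naphthalen-2-yl has the same effect alongside the 2,6-dichlorophenyl group also remains open.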